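A few compounds are considered here, and "the series" means these few. Any claim that something is new, unique, unknown or untested is made for them only; others in the source may bear on it.

In an ADME assay on HaCaT cells (Homo sapiens) for cytotoxicity, read by MTT assay, with a stated time of 72 h (on this read-out lower numbers stand for stronger inhibition and higher numbers for weaker inhibition), the measured compounds are:

compound 1, `CCCCNC1=CC(=O)C=C(C(C)(C)C)C1=O`: 11000 nM
compound 2, `CNC1=CC(=O)C=C(C(C)(C)C)C1=O`: 10000 nM
compound 3, `CNC1=CC(=O)C(C(C)(C)C)=CC1=O`: 28000 nM

Compound 4, `CCCCNC1=CC(=O)C(C(C)(C)C)=CC1=O`, awaits measurement in this assay. It differs from compound 3 by propyl in place of hydrogen on a saturated chain carbon bound to an amine nitrogen. The same change is seen between the measured pair, where compound 1 differs from compound 2 by propyl in place of hydrogen on a saturated chain carbon bound to an amine nitrogen, and there it gave a 1.1-fold higher number from compound 2 to compound 1 (0.04 log units; within the scatter). The cores of compound 3 and compound 2 share the same atoms joined differently; that difference between the two cores is not broken down here. Because a 1.1-fold higher number from compound 2 to compound 1 (0.04 log units; within the scatter) was within the scatter, the step from compound 3 to compound 4 is expected to be small as well, estimated at a 1.1-fold higher number from compound 3 to compound 4 (0.03 log units; within the scatter). Compound 4 is therefore estimated at 30000 nM, expected to fall between 15000 nM and 60000 nM.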

Compound 4, half-maximal inhibitory concentration: > 100000 nM
Compound 4: a limit, no number; the forecaster's own chance of this, stated with the estimate: 10%; middle value at least 3.3-fold (0.52 log units) away from the limit.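

In this assay, the change from methylamino to butylamino does not carry over unchanged from one core to the other: the same change on two cores in this assay, a 1.1-fold higher number (0.04 log units; within the scatter) from compound 2 to compound 1 and an at least 3.5-fold higher number (0.55 log units; beyond the scatter) from compound 3 to compound 4, at least 3.2-fold (0.51 log units) apart, beyond the scatter of two such steps
Compound 4 gives > 100000 nM, which is a limit of the assay and not a number. The step therefore reads an at least 3.5-fold higher number from compound 3 to compound 4 (0.55 log units; beyond the scatter), so the pairs show that the size of this change depends on the core, but they do not show how large the step on the core of compound 3 really is, or why the two cores part.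

The compounds shown leave open how an ethyl or a hexyl chain on the amine nitrogen would behave on either core. They also leave open whether a chain ending in a carboxylic acid would follow the same course.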